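From compound 1 to compound 3: one ring group exchanged

A few compounds are considered here, and "the series" means these few. Any claim that something is new, unique, unknown or untested is made for them only; others in the source may bear on it.

Compound 1 `Cc1ccc(CO/N=C2/C(c3c[nH]c4ccccc34)=Nc3ccccc32)cc1` - 25400 nM
Compound 2 `Cc1ccc(CO/N=C2/C(c3c[nH]c4ccc(Br)cc34)=Nc3ccc(Br)cc32)cc1` - 15100 nM

Both numbers come from a functional assay on SPCA2 cells (Homo sapiens) for cytotoxicity, read by MTT assay, with a stated time of 2 days (on this read-out lower numbers stand for stronger inhibition and higher numbers for weaker inhibition), and lie within the scatter of each other, so compound 1 cannot be ranked apart from compound 2 and shares its place on this short scale.

Compound 3 `Fc1ccc(CO/N=C2/C(c3c[nH]c4ccccc34)=Nc3ccccc32)c(Cl)c1` keeps the core of compound 1 and carries 2-chloro-4-fluorophenyl in place of 4-methylphenyl on a saturated chain carbon bound to an oxygen on an unsaturated carbon. Counted, the exchange reads 2-chloro-4-fluorophenyl in place of 4-methylphenyl on a saturated chain carbon bound to an oxygen on an unsaturated carbon and nothing else differs. Within the data shown here, no measured pair shows a change at this place, so the step has no direct precedent. Among the measured compounds shown here, the only guide is that compound 1 at 25400 nM and compound 2 at 15100 nM stay within the scatter of each other. In this assay a step no larger than the scatter is therefore expected, leaning slightly towards a lower number. The estimated change is a 1.6-fold lower number from compound 1 to compound 3 (0.20 log units; within the scatter) and it stays within that scatter. For compound 3 the estimated value is 16000 nM with an expected range from 6000 nM to 42000 nM in this measurement.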

Compound 3, half-maximal inhibitory concentration: 19500 nM
Beside the measured number, compound 3's estimate is 1.2-fold (0.09 log units) below it; measured number inside the range.
By their numbers in this assay, from the lowest: compounds 2, 3 and 1 (each within the scatter of the next).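

Among these compounds, compound 3 gives the first reading of a change on a saturated chain carbon bound to an oxygen on an unsaturated carbon, and in this assay the exchange of 4-methylphenyl for 2-chloro-4-fluorophenyl comes to a 1.3-fold lower number from compound 1 to compound 3 (0.11 log units; within the scatter) and thus stays inside the scatter. This position therefore accepts a ring bearing chlorine and fluorine in place of one bearing methyl, with no change that this cell read-out can resolve, so this particular exchange offers no handle on the cytotoxicity of the series. Nothing measured here offers an explanation for this flat result.

The step moves chlorine and fluorine together, so it cannot say whether either halogen alone would act differently from the other, or whether the two happen to offset each other. Both groups are also substituted phenyl rings on the same chain carbon, which leaves open whether an amine or a carboxylic acid on that ring, or a longer chain leading to it, would shift the number beyond the scatter.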